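The source may report more compounds than this note shows. Statements on the series, on what has been measured and on what is new or still open speak of the compounds shown alone.

Working notes on the series. Three compounds on a shared core have been taken through a functional assay on the whole organism (strain Wistar albino) for inhibition, with Rattus norvegicus as the target, read by paw edema, with stated times of 30 min and 2.5 h, at a dose of 20 mg/kg; a higher number here means more inhibition at the dose given (going by the name of the read-out), a lower number less inhibition. Compound 1 `Cc1ccc([C@H]2CC(c3ccccc3)=NN2c2ncc(Br)cn2)cc1` gives 72% in this assay. Going by the values given here, compound 2 `Clc1ccc([C@H]2CC(c3ccccc3)=NN2c2ncc(Br)cn2)cc1`, in which a chloro replaces the methyl on an aromatic carbon, gives 72%; the step of no change at the digits printed from compound 1 to compound 2 (within the scatter) is the only single-point comparison available among the measured compounds. Compound 3 `COc1ccc([C@H]2CC(c3ccc(Cl)cc3)=NN2c2ncc(Br)cn2)cc1` gives 69% in this assay, and its number lies within the scatter of both compound 1 and compound 2, so no ordering among the three can be read from these values.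

Compound 4 `Clc1ccc(C2=NN(c3ncc(Br)cn3)[C@@H](c3ccccc3)C2)cc1` has not been measured in this assay. Relative to compound 3 the difference is hydrogen in place of methoxy on an aromatic carbon; the group sits para to a large group on a six-membered aromatic ring of carbon only. Among the compounds with values here, the one step that bears on a change at this position is no change at the digits printed from compound 1 to compound 2 (within the scatter), which exchanged one substituent for another on that ring without moving the number beyond the scatter. Within the data shown here, removing the methoxy altogether is a different change from that exchange, and no measured pair covers loss of a substituent at this place. On the evidence at hand the step of no change at the digits printed from compound 3 to compound 4 (within the scatter) is expected to stay within the scatter, in no particular direction. Compound 4 is therefore estimated at 69% in this assay, with a range from 58% to 79%.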

Compound 4, a percentage reported as inhibition, in the whole organism at one dose (the size of the read-out at that dose, not a potency): 70%
Estimate against measurement, compound 4: 1 percentage points below; the measured number falls inside the stated range.
By their numbers in this assay, from the lowest: compounds 3, 4, 1 and 2 (each within the scatter of the next).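

The change here is removal, not exchange: this assay moves only a number 1 percentage points higher from compound 3 to compound 4 (within the scatter) when methoxy gives way to hydrogen on the aromatic carbon para to a large group. The earlier step, no change at the digits printed from compound 1 to compound 2 (within the scatter), exchanged one substituent for another and so could not show how this ring behaves with no substituent at that place; this pair shows that, with the rest of compound 3 held fixed, the read-out at this dose stays within the scatter without the methoxy. Nothing available explains this result, and no measured property of either compound bears on it.

The compounds shown leave open whether a group of another kind at this place, such as an amine, a carboxylic acid or a longer alkoxy chain, would move the number beyond the scatter. All the numbers also come from a single dose, so they do not settle whether compound 3 and compound 4 would stay together at other doses.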